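From a hydroxyalkyl amine to a methoxybenzyl amine

The source may hold more compounds than are shown below. What is called first, only, known or untested is meant among the compounds shown, and "the series" means these compounds.

Measured compounds:
compound 1 `OCCCCNCc1nc2c(OCC3CCCCC3)cccc2[nH]1` gives 44.3%
compound 2 `OCCCCCNCc1nc2c(OCC3CCCCC3)cccc2[nH]1` gives 23.7%
compound 3 `CCCC(CO)NCc1nc2c(OCC3CCCCC3)cccc2[nH]1` gives 73.3%

All three share one core and differ only in the group on the amine nitrogen. In an assay on cells for inhibition of interleukin-5 receptor subunit alpha (Mus musculus), read by WST assay, with a stated time of 48 h, tested at 30 uM, in the presence of a further agent that is not named here (on this read-out higher numbers stand for more inhibition at the one concentration tested (going by the name of the read-out) and lower numbers for less inhibition), compound 3 gives 73.3%, the highest of the three numbers. The steps toward it are both beyond the scatter: a number 29 percentage points higher from compound 1 to compound 3 (beyond the scatter) and a number 49.6 percentage points higher from compound 2 to compound 3 (beyond the scatter). Between the two straight hydroxyalkyl chains, the number falls: a number 20.6 percentage points lower from compound 1 to compound 2 (beyond the scatter).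

Compound 4 `COc1ccc(CNCc2nc3c(OCC4CCCCC4)cccc3[nH]2)cc1` is the unmeasured member. Its change from compound 3 is 4-methoxybenzyl in place of 1-(hydroxymethyl)butyl on an amine nitrogen. The hydroxy-bearing chain is exchanged for a group with an aromatic ring and no hydrogen-bond donor. For the measured compounds named here, none of the measured steps swaps a hydroxyalkyl chain for a ring; they only compare one hydroxyalkyl chain with another, so they give no direct guide, and the step from 2 to 3 shows that this position moves the number by a large amount.

Compound 4 is therefore expected to land well below compound 3, and the estimated step is a number 28.3 percentage points lower from compound 3 to compound 4 (beyond the scatter). The estimate for compound 4 is 45%, within a wide range from 15% to 75%.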

Compound 4, a percentage reported as inhibition, at one concentration (the size of the read-out at that concentration, not a potency): 43.3%
Beside the measured number, compound 4's estimate is 1.7 percentage points above it; the measured number falls inside the stated range.
By their numbers in this assay, from the lowest: compound 2; then compounds 4 and 1 (each within the scatter of the next); then compound 3.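

In this assay the 4-methoxybenzyl group, which puts one six-membered aromatic ring and 0 hydrogen-bond donors on the amine nitrogen, shows that this position can carry more than a hydroxyalkyl chain: there is a number 30 percentage points lower from compound 3 to compound 4 (beyond the scatter) but also a number 19.6 percentage points higher from compound 2 to compound 4 (beyond the scatter) and the number therefore sits among those of the hydroxy-bearing chains, not under all of them. Against the straight 4-hydroxybutyl chain the result is a number 1 percentage points lower from compound 1 to compound 4 (within the scatter) and these two very different groups cannot be told apart here. A hydroxy group on this substituent is thus not needed for a number of this size, and compound 2 shows that having one does not secure it, although compound 3, with its branched 1-(hydroxymethyl)butyl chain, remains the highest of the four.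

The compounds shown do not separate the aromatic ring from its methoxy group, so a plain benzyl group on this nitrogen would be the telling comparison. They also leave open whether the hydroxy group of compound 3 matters within its own branched chain, which a methoxy group in its place could test. Nothing given here explains why the number moves at this position.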